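The source may report more compounds than this note shows. Statements on the series, on what has been measured and on what is new or still open speak of the compounds shown alone.

Measured so far:
Compound 1 `Cc1cc(C)cc(/C=C(\C(=O)c2ccc(Cl)cc2)S(=O)(=O)c2ccc(Br)cc2)c1`: in a functional assay on DU-145 cells (Homo sapiens) for inhibition, read by trypan blue exclusion, with a stated time of 96 h (a lower number here means a stronger inhibitor of growth, a higher number a weaker inhibitor of growth), compound 1 gives 10000 nM.
Compound 2 `O=C(/C(=C\c1c(O)cc(O)cc1O)S(=O)(=O)c1ccc(Br)cc1)c1ccc(Cl)cc1`: in this assay compound 2 gives only a limit, > 100000 nM.

Within the data shown here, compound 1 holds the only number in this assay. The other value shown is a limit (the limit of > 100000 nM in this assay, at which 1 of the 2 values shown sits). Among the measured compounds shown here, the one measured step, an at least 10-fold higher number from compound 1 to compound 2 (1.00 log units; beyond the scatter), concerns the aryl on the chain carbon, not the sulfonyl side. Compound 3 `Cc1ccc(CS(=O)(=O)/C(=C/c2cc(C)cc(C)c2)C(=O)c2ccc(Cl)cc2)cc1` differs from compound 1 by 4-methylbenzyl in place of 4-bromophenyl on a sulfonyl sulfur. For the measured compounds named here, no measured step touches the sulfonyl substituent, so no change beyond the scatter is expected in this assay. Compound 3 is estimated at 10000 nM (range 3000 nM to 40000 nM), an expected step of no change at the digits printed from compound 1 to compound 3 (within the scatter).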

Compound 3, concentration for 50% growth inhibition: 10000 nM
The estimate for compound 3 equals the measured number at the digits printed; the measured number falls inside the stated range.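

In this assay, among these compounds, the sulfonyl side gets its first read: 4-methylbenzyl in place of 4-bromophenyl on the sulfonyl sulfur gives no change at the digits printed from compound 1 to compound 3 (within the scatter), whereas the only earlier step concerned the aryl on the chain carbon. At this position, then, a benzyl group and a phenyl group read alike in the one pair shown. Nothing shown bears on why these two groups read alike. Still open, going by these compounds, is whether a carboxylic acid, an amine or a longer chain on the sulfonyl sulfur would read the same. Also open, on these data alone, is whether this swap holds with 2,4,6-trihydroxyphenyl on the chain carbon.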